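Replacing fluoro with tert-butyl on compound 3

A few compounds are considered here, and "the series" means these few. Any claim that something is new, unique, unknown or untested is made for them only; others in the source may bear on it.

In an ADME assay on MDBK cells (Bos taurus) for cytotoxicity (a higher number here means that more compound is tolerated, a lower number that less compound is tolerated), compound 3 `Fc1ccc(Cn2ccc3nc(-c4ccccc4)nc-3c2)cc1` gives > 100000 nM, which is a limit of the assay and not a number. Compound 1 `Fc1cccc(F)c1Cn1ccc2nc(-c3ccccc3)nc-2c1` gives > 100000 nM, also a limit. Compound 2 `Cc1cccc(Cn2ccc3nc(-c4ccccc4)nc-3c2)c1` gives > 100000 nM, again a limit. The measurements so far come down to the limit of > 100000 nM in this assay, at which 3 of the 3 values shown sit.

Compound 4 `CC(C)(C)c1ccc(Cn2ccc3nc(-c4ccccc4)nc-3c2)cc1` is still unmeasured. It differs from compound 3 by one change: tert-butyl in place of fluoro on an aromatic carbon. This places tert-butyl in place of fluoro on an aromatic carbon, para to a large group.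

The closest evidence comes from three measured exchanges on the same phenyl group: a step that the two limits leave unreadable from compound 2 to compound 3, a step that the two limits leave unreadable from compound 1 to compound 3 and a step that the two limits leave unreadable from compound 1 to compound 2. None of them gives a size, and none brings in tert-butyl. On these data alone, they therefore offer no measured support for a shift in either direction, and the new group remains untested.

With compound 3 at > 100000 nM, a limit, the expectation in this assay is that compound 4 stays close to that level, though a measurable value would not be a surprise. The expected change is a number no higher from compound 3 to compound 4 (the limit leaves the size open). The estimate for compound 4 is 100000 nM, with an expected range from 30000 nM to 200000 nM.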

Compound 4, half-maximal cytotoxic concentration: 22000 nM
Compound 4: middle estimate off by 4.5-fold (0.66 log units), on the high side; the whole stated range lies above it.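

In this assay, going by these compounds alone, the aromatic carbon para to a large group proves able to register a change, as tert-butyl in place of fluoro gives an at least 4.5-fold lower number from compound 3 to compound 4 (0.65 log units; beyond the scatter) and so provides the first readable step. The exchange puts four carbon atoms where one fluorine stood, and neither atom count nor ring count changes in any other way, since both groups carry no hydrogen-bond donors, no hydrogen-bond acceptors and no net charge. Within the data shown here, the steps among compound 1, compound 2 and compound 3 cannot be read, so the earlier compounds could not show whether any phenyl substitution moves this read-out at all, and compound 4 is the only one that leaves the ceiling: the limit of > 100000 nM in this assay, at which 3 of the 4 values shown sit.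

On these data alone, the full size of the step stays open, and one readable exchange cannot show whether the drop follows the size of the group or belongs to tert-butyl alone. Also open, as far as these compounds go, is what an intermediate group such as isopropyl, or a carboxylic acid or an amine, would do on the same aromatic carbon.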